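The source may report more compounds than this note shows. Statements on the series, on what has been measured and on what is new or still open speak of the compounds shown alone.

Measured to date:
- compound 1, `CSc1ncc(C2C(C(=O)OCC(C)C)=C(C)NC(C)=C2C(=O)OCC(C)C)n1Nc1ccccc1`, in an assay on isolated protein (strain albino) for antagonist activity at Voltage-dependent L-type calcium channel subunit alpha-1C (Cavia porcellus) (on this read-out higher numbers stand for weaker inhibition and lower numbers for stronger inhibition), compound 1 gives 6.71 nM
- compound 2, `CCCOC(=O)C1=C(C)NC(C)=C(C(=O)OCCC)C1c1cnc(SC)n1Nc1ccccc1`, in this assay compound 2 gives 2.29 nM
- compound 3, `CSc1ncc(C2C(C(=O)OCCCc3ccccc3)=C(C)NC(C)=C2C(=O)OCCCc2ccccc2)n1Nc1ccccc1`, in this assay compound 3 gives 3.15 nM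

Compound 3 sits second highest of the three numbers. Its gap to compound 2 lies within the scatter, so no order between these two can be read. Its gap to compound 1 lies beyond the scatter, compound 1 showing the higher number of the pair. Going by the values given here, no single-point step between measured compounds is available, so the whole spread of the three diesters is the only guide.

Compound 4, `CSc1ncc(C2C(C(=O)OCCCc3ccccc3)=C(C)NC(C)=C2C(=O)OC(C)C)n1Nc1ccccc1`, differs from compound 3 in one place: isopropyl in place of 3-phenylpropyl on an oxygen next to a carbonyl group. Both remaining diester variants fall close to compound 3, so the step of a 1.1-fold higher number from compound 3 to compound 4 (0.05 log units; within the scatter) is expected to stay within the scatter, with no clear direction. Compound 4 is estimated at 3.5 nM, within 1.5 nM to 9 nM.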

Compound 4, half-maximal inhibitory concentration: 6.22 nM
Estimate against measurement, compound 4: 1.8-fold (0.25 log units) below; measured number inside the range.
By their numbers in this assay, from the lowest: compounds 2, 3, 4 and 1 (each within the scatter of the next, the first and the last beyond it).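

In this assay, going by these compounds alone, isopropyl in place of 3-phenylpropyl on an oxygen next to a carbonyl group gives a 2.0-fold higher number from compound 3 to compound 4 (0.30 log units; within the scatter), the first single-place step. The loss of the aromatic ring and of most of the chain at this position thus leaves no readable change in the number. Nothing at hand accounts for the size of this step.

Every group shown on this oxygen is pure carbon, so the effect of an amine or a carboxylic acid at the end of the chain remains open. Also open, from the compounds shown here alone, is whether the same swap gives a similar step with a different group on the second ester.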